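Carbamate ester swap on a shared core, full agonism retained

The compounds below may be only part of what the source reports. "The series", "measured", "known", "first", "only" and "open" are said of these compounds alone.

Measured compounds:
compound 1 `CC(C)(C)OC(=O)N1CCC(O[C@H]2CC[C@@H](Oc3ccc(S(C)(=O)=O)cc3)CC2)CC1` — 120%
compound 2 `CC(C)(C)OC(=O)N1CCC(O[C@H]2CC[C@H](Oc3ccc(S(C)(=O)=O)cn3)CC2)CC1` — 111%
compound 3 `CC1(OC(=O)N2CCC(O[C@H]3CC[C@H](Oc4cnc(S(C)(=O)=O)cn4)CC3)CC2)CC1` — 118%

Of the compounds shown here, three share a core and have been tested in a functional assay on isolated protein for agonist activity at Glucose-dependent insulinotropic receptor (Homo sapiens), read by HTRF and cAMP accumulation; a higher number here means a larger maximal response, a lower number a smaller maximal response. Compound 1 `CC(C)(C)OC(=O)N1CCC(O[C@H]2CC[C@@H](Oc3ccc(S(C)(=O)=O)cc3)CC2)CC1` reaches 120%, compound 2 `CC(C)(C)OC(=O)N1CCC(O[C@H]2CC[C@H](Oc3ccc(S(C)(=O)=O)cn3)CC2)CC1` gives 111%, and compound 3 `CC1(OC(=O)N2CCC(O[C@H]3CC[C@H](Oc4cnc(S(C)(=O)=O)cn4)CC3)CC2)CC1` gives 118%. Compound 3 stands second of the three numbers, yet its gap to compound 1 and its gap to compound 2 both lie within the scatter of repeated measurements, so the three compounds cannot be ordered against each other on this read-out.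

Compound 4 `CS(=O)(=O)c1cnc(O[C@H]2CC[C@H](OC3CCN(C(=O)OC4CCOC4)CC3)CC2)cn1` has not yet been measured in this assay. It differs from compound 3 in one place: oxolan-3-yl in place of 1-methylcyclopropyl on an oxygen next to a carbonyl group. Among the compounds with values here, no measured pair in this set isolates a change of that kind, so no measured step can guide the expectation. The account rests on the observation that the three measured compounds, with different groups across the shared core, all give largest responses close to one another in this assay. Compound 4 is therefore expected to show a step from compound 3 of a number 3 percentage points lower from compound 3 to compound 4 (within the scatter), that is, none beyond the scatter. The estimate for compound 4 in this assay is 115%, with a range from 100% to 130%.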

Compound 4, largest response reached (Emax), in percent of the reference or control that the assay uses: 105%
Beside the measured number, compound 4's estimate is 10 percentage points above it, and the stated range covers the measured number.
By their numbers in this assay, from the lowest: compounds 4, 2, 3 and 1 (each within the scatter of the next, the first and the last beyond it).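

In this assay, within the data shown here, the ester group on the carbamate proves able to move the response: oxolan-3-yl in place of 1-methylcyclopropyl on an oxygen next to a carbonyl group gives a number 13 percentage points lower from compound 3 to compound 4 (beyond the scatter) and this is the first change in one place that the set can read. The entering group differs in two counted ways, with one more heavy atom and one hydrogen-bond acceptor, and this single step cannot separate the two. Nothing available bears on why the response differs between these two esters.

The compounds shown leave open whether the ring oxygen matters at all, as they include no cyclopentyl ester, the all-carbon counterpart of oxolan-3-yl. They also leave open whether the same swap would give a similar step in the shared core of compound 1 or compound 2.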